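This account rests on a few compounds, and the source may have more. Where it says the series, first, only, none or still open, it means among the compounds named here.

The study concerns three measured anilides and a fourth that still awaits testing. Compound 1, `CCS(=O)(=O)Nc1ccc(NC(=O)c2ccc(Cl)cc2)cc1C`, is the parent; compound 2, `Cc1cc(NC(=O)c2ccc(Cl)cc2)ccc1NS(=O)(=O)C(F)(F)F`, carries a trifluoromethyl on the sulfonyl sulfur in its place; compound 3, `CCS(=O)(=O)Nc1ccc(NC(=O)c2cccc(C(F)(F)F)c2)cc1OC`, stands on a second core; and compound 4, `COc1cc(NC(=O)c2cccc(C(F)(F)F)c2)ccc1NS(=O)(=O)C(F)(F)F`, pairs that second core with the same trifluoromethyl sulfonyl group.

In an ADME assay on RAW264.7 cells (Mus musculus) for cytotoxicity, read by MTT assay, with a stated time of 48 h (on this read-out lower numbers stand for stronger inhibition and higher numbers for weaker inhibition), compound 1 gives 68700 nM. In this assay compound 2 gives 35400 nM. The change between them is trifluoromethyl in place of ethyl on a sulfonyl sulfur and it produced a 1.9-fold lower number from compound 1 to compound 2 (0.29 log units; within the scatter). In this assay compound 3 gives 84800 nM; its number is the highest of the three, though its gap to compound 1 lies within the scatter, while the gap from compound 3 down to compound 2 lies beyond it. How the core of compound 3 differs from the core of compound 1 is not broken down here.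

Compound 4 arises from compound 3 by trifluoromethyl in place of ethyl on a sulfonyl sulfur. Within the data shown here, this is the same change as the one from compound 1 to compound 2, on a sulfonyl sulfur with the same neighbour. Because the earlier instance gave a 1.9-fold lower number from compound 1 to compound 2 (0.29 log units; within the scatter), a comparable and modest downward step is expected here, estimated as a 1.7-fold lower number from compound 3 to compound 4 (0.23 log units; within the scatter). Resting on that single precedent, compound 4 is estimated to give 50000 nM in this assay, with a plausible range from 25000 nM to 100000 nM.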

Compound 4, half-maximal inhibitory concentration: 75200 nM
For compound 4 the middle estimate is 1.5-fold (0.18 log units) below the measured one; measured number inside the range.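

In this assay, trifluoromethyl in place of ethyl on a sulfonyl sulfur gives a 1.1-fold lower number from compound 3 to compound 4 (0.05 log units; within the scatter), so on the core of compound 3 the change leaves the number within the scatter, as it did on the core of compound 1. Set side by side, the two instances do not differ, and the change carries from one core to the other without any visible break: the same change on two cores in this assay, a 1.9-fold lower number (0.29 log units; within the scatter) from compound 1 to compound 2 and a 1.1-fold lower number (0.05 log units; within the scatter) from compound 3 to compound 4, 1.7-fold (0.24 log units) apart, within the scatter of two such steps. Among these compounds, this shows only that the two cores agree in giving no step that can be told from repeat measurement; it does not show that the change itself has a real effect on the number on either core, and two cores cannot establish a rule for the whole series.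

The compounds shown leave open whether a methyl, a propyl or a phenyl group on the sulfonyl sulfur would also stay within the scatter of the ethyl compounds. They also leave open how the same exchange of ethyl for trifluoromethyl would read on a core carrying an amine or a carboxylic acid.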